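Pyrazolopyrimidine-linked enones: working notes on compound 4

A few compounds are considered here, and "the series" means these few. Any claim that something is new, unique, unknown or untested is made for them only; others in the source may bear on it.

Within the data shown here, three measured members so far. In a functional assay on DU-145 cells (Homo sapiens) for antiproliferative activity, read by MTT assay, with a stated time of 24 h (on this read-out lower numbers stand for stronger inhibition and higher numbers for weaker inhibition), compound 1 `COc1cc(C(=O)/C=C/c2cc(-c3cc(OC)c(OC)c(OC)c3)n3nc(-c4ccccc4)cc3n2)cc(OC)c1OC` gives 34900 nM, compound 2 `COc1ccc(/C=C/C(=O)c2cc(-c3ccc(OC)c(OC)c3)n3nc(-c4ccccc4)cc3n2)cc1` gives 14900 nM, and compound 3 `COc1ccc(-c2cc(/C=C/C(=O)c3ccc(OC)c(OC)c3)nc3cc(-c4ccccc4)nn23)cc1` gives 16400 nM. Compound 2 carries the lowest number of the three, but the gap to compound 3 lies within the scatter of the method, so no order between those two can be drawn; only the gap to compound 1 is beyond the scatter. Among the measured compounds shown here, no pair among the measured compounds differs in a single place, so no single-point step has been quantified.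

Compound 4 `COc1ccc(-c2cc(/C=C/C(=O)c3ccc(C)c(C)c3)nc3cc(-c4ccccc4)nn23)cc1OC` is the next candidate for this assay. Against compound 2 the change is 2-((3,4-dimethylphenyl)carbonyl)ethenyl in place of (2-(4-methoxyphenyl)ethenyl)carbonyl on an aromatic carbon. The trimethoxyphenyl-bearing compound 1 carries the highest number, while compound 2 and compound 3 sit close together despite different arrangements of the enone and the methoxyphenyl groups; the change to compound 4 removes two methoxy oxygens in favour of methyl groups. For the measured compounds named here, with no quantified step to lean on, compound 4 is expected to land near compound 2, with a step from compound 2 to compound 4 of a 1.2-fold higher number from compound 2 to compound 4 (0.08 log units; within the scatter), most likely not beyond the scatter. The estimate for compound 4 in this assay is 18000 nM, in a range from 7000 nM to 45000 nM.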

Compound 4, half-maximal inhibitory concentration: 12100 nM
Beside the measured number, compound 4's estimate is 1.5-fold (0.17 log units) above it; low and high end bracket the measured number.
By their numbers in this assay, from the lowest: compounds 4, 2 and 3 (each within the scatter of the next); then compound 1.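

The series now has its first quantified single-place step: in this assay, putting 2-((3,4-dimethylphenyl)carbonyl)ethenyl in place of (2-(4-methoxyphenyl)ethenyl)carbonyl on this aromatic carbon gives a 1.2-fold lower number from compound 2 to compound 4 (0.09 log units; within the scatter). This position therefore accepts an exchange in which the order of carbonyl and ethenyl in the chain is turned round and the aryl substituents differ, with both groups at 12 heavy atoms, and no separation between compound 2 and compound 4 can be read from the result. The exchange also takes the group from 2 hydrogen-bond acceptors to 1, again with the step inside the scatter, so neither the order of the chain nor that count shows up as a resolved difference in this pair. Nothing on hand bears on why the number stays within the scatter.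

Going by these compounds, the step joins the chain order and the aryl substituents in one change, so the share of each remains open. Also open is how the assay responds at this position to an aryl ring carrying an amine or a carboxylic acid, groups absent from the compounds shown.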